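Swapping Trifluoromethyl for Trifluoromethoxy Across Two Cores

This account rests on a few compounds, and the source may have more. Where it says the series, first, only, none or still open, it means among the compounds named here.

Of the compounds shown here, three have been measured in an ADME assay on liver for metabolic stability, with Liver microsome (Rattus norvegicus) as the target, read by LC-MS, using microsomes, with a stated time of 5 h; a higher number here means faster removal of the compound, a lower number slower removal. Compound 1, `O[C@H](c1ccccn1)[C@]1(c2cccc(OC(F)(F)F)c2)C[C@H](O)C1`, gives 117 mL/min/kg. Compound 2, `O[C@H](c1ccccn1)[C@]1(c2cccc(C(F)(F)F)c2)C[C@H](O)C1`, gives 183 mL/min/kg. Compound 3, `C[C@]1(O)C[C@@](c2ccc(C(F)(F)F)cc2)([C@H](O)c2ccccn2)C1`, gives 150 mL/min/kg. The three numbers sit close together, and none of them can be set apart from the others.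

Compound 1 differs from compound 2 in one place: trifluoromethoxy in place of trifluoromethyl on an aromatic carbon. The step that came with it was a 1.6-fold lower number from compound 2 to compound 1 (0.19 log units; within the scatter), so the exchange left the clearance essentially where it was.

Compound 4, `C[C@]1(O)C[C@@](c2ccc(OC(F)(F)F)cc2)([C@H](O)c2ccccn2)C1`, is not yet measured. It carries the same exchange relative to compound 3: trifluoromethoxy in place of trifluoromethyl on an aromatic carbon. The surroundings of the place are not the same, though: in compound 1 the new group sits meta to a large group, in compound 4 it sits para to a large group, so this is the same kind of change rather than the same change. The difference between the core of compound 2 and the core of compound 3 is not broken down here.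

The expectation for compound 4 rests on one earlier instance only. Since the number for compound 3 is 150 mL/min/kg, and the earlier exchange moved the number by only a small amount, the step from compound 3 to compound 4 is expected to be a 1.4-fold lower number from compound 3 to compound 4 (0.15 log units; within the scatter). Compound 4 is therefore estimated at 105 mL/min/kg, with a likely span from 55 mL/min/kg to 200 mL/min/kg.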

Compound 4, clearance: 133 mL/min/kg
Beside the measured number, compound 4's estimate is 1.3-fold (0.10 log units) below it, within the range that was stated.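

In this assay, putting trifluoromethoxy in place of trifluoromethyl on the second core gave a 1.1-fold lower number from compound 3 to compound 4 (0.05 log units; within the scatter), so this pair of compounds cannot be told apart in this assay. Set beside the same exchange on the first core, the result is consistent, and the two steps cannot be separated from each other: the same change on two cores in this assay, a 1.6-fold lower number (0.19 log units; within the scatter) from compound 2 to compound 1 and a 1.1-fold lower number (0.05 log units; within the scatter) from compound 3 to compound 4, 1.4-fold (0.14 log units) apart, within the scatter of two such steps. Within the data shown here, this shows that on both cores the exchange left the clearance within the usual scatter, but it rests on only two pairs and does not show that the exchange has no effect at all, that the two steps are truly equal in size, or that the result would hold on a further core.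

All four compounds carry either trifluoromethyl or trifluoromethoxy on the aromatic ring of carbon only, so these data say nothing about how a quite different group there, such as a nitrile, an amine or a carboxylic acid, would behave. Whether any such group could move the clearance by more than the scatter, on either core, remains an open question.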